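A Fluorophenyl for a Methylphenyl on a Shared Core

The source may report more compounds than this note shows. Statements on the series, on what has been measured and on what is new or still open speak of the compounds shown alone.

Four close analogues share one core, and only one of them carries a number. Compound 1 `COc1cc2c(Oc3ccc(NC(=O)c4cc(-c5ccc(F)cc5)ccn4)cc3F)ccnc2cc1OCCCN1CCN(C)CC1` has no reported result in a functional assay on U-87MG ATCC cells (Homo sapiens) for cytotoxicity, read by MTT assay, with a stated time of 72 h; a higher number here means a weaker inhibitor, a lower number a stronger inhibitor: for compound 1 the entry reads "not determined" (no result reported). For the measured compounds named here, compound 2 `COc1cc2c(Oc3ccc(NC(=O)c4cc(-c5ccc(C)cc5)ccn4)cc3F)ccnc2cc1OCCCN1CCCC1` is the only measured member of the set: in this assay compound 2 gives 560 nM. Compound 3 `COc1cc2c(Oc3ccc(NC(=O)c4cc(-c5ccccc5C)ccn4)cc3F)ccnc2cc1OCCCN1CCCC1` has, like compound 1, no reported result in this assay, and for compound 3 the entry likewise reads "not determined" (no result reported), so compound 3 stands nowhere on the numbers shown; it is one of two entries without a value.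

Compound 4 `COc1cc2c(Oc3ccc(NC(=O)c4cc(-c5ccc(F)cc5)ccn4)cc3F)ccnc2cc1OCCCN1CCCC1` differs from compound 3 in one place: 4-fluorophenyl in place of 2-methylphenyl on an aromatic carbon. Going by the values given here, no measured step is known for this change, and the single value of compound 2 gives no direction for it. The change is therefore expected to move this assay by no more than the usual scatter in either direction, with the value of compound 2 as the only anchor.

Compound 4 is estimated to give 600 nM in this assay, within a range from 200 nM to 2000 nM.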

Compound 4, half-maximal inhibitory concentration: 1780 nM
Estimate against measurement, compound 4: 3.0-fold (0.47 log units) below, and the stated range covers the measured number.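

For the compounds shown here, compound 4 supplies the first readable step of the set: in this assay there is a 3.2-fold higher number from compound 2 to compound 4 (0.50 log units; beyond the scatter) with fluoro in place of methyl on the phenyl group. The group carried on that phenyl therefore matters here, and in this pair methyl goes with the lower number, meaning the stronger inhibitor, while the change from the 2-methylphenyl of compound 3 cannot be read, as compound 3 has no number. Nothing given here accounts for the step.

From the compounds shown here alone, one pair cannot show whether this order extends beyond methyl and fluoro, so a chloro group, a methoxy group or an amine on the same phenyl remains open. Going by these compounds, whether the step would hold on any other compound also remains open.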